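Removing a chloro group from compound 1

The compounds below may be only part of what the source reports. "The series", "measured", "known", "first", "only" and "open" are said of these compounds alone.

Compound 1 `Nc1ccc(-c2cc(=O)c3c(N)c(Cl)cc(Cl)c3o2)cc1`: 610 nM
Compound 2 `Nc1ccc(-c2cc(=O)c3c(N)c(Cl)ccc3o2)cc1`: > 10000 nM (a limit of the assay)
Compound 3 `Nc1ccc(-c2cc(=O)c3c(N)ccc(Cl)c3o2)cc1`: not yet measured

For the measured compounds named here, in a functional assay on MCF7 cells (Homo sapiens) for inhibition, in the presence of a further agent that is not named here (a higher number here means a weaker inhibitor, a lower number a stronger inhibitor), compound 1 gives 610 nM, the only actual number so far. The reading for compound 2 is a limit, so the comparison rests on (the limit of > 10000 nM in this assay, at which 1 of the 2 values shown sits).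

Compound 3 differs from compound 1 by hydrogen in place of chloro on an aromatic carbon. The chloro group it loses sits ortho to an amino group, and compound 2 keeps that chloro group while losing the other one.

Going by the values given here, one measured step bears on this change, the same kind of exchange made at the other carbon. It is large and beyond the scatter: an at least 16-fold higher number from compound 1 to compound 2 (1.21 log units; beyond the scatter). Among the compounds with values here, with only that step as a guide, and at a different carbon, a higher number is expected for compound 3, though probably a less extreme one, and its size is quite uncertain. The expected step is a 4.9-fold higher number from compound 1 to compound 3 (0.69 log units; beyond the scatter). For compound 3 the estimated value in this assay is 3000 nM, with an expected range from 600 nM to 10000 nM.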

Compound 3, half-maximal inhibitory concentration: 250 nM
Estimate against measurement, compound 3: 12-fold (1.08 log units) above, outside the stated range (below it).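

In this assay, the chloro group ortho to an amino group is not needed for activity in this series: replacing it with hydrogen gives a 2.4-fold lower number from compound 1 to compound 3 (0.39 log units; beyond the scatter). The same exchange at the other carbon gives an at least 16-fold higher number from compound 1 to compound 2 (1.21 log units; beyond the scatter), so the two chloro groups of compound 1 do not count alike, and the direction of this change depends on the carbon where it is made. Compound 2 reads at a limit, so the size of its step stays open on one side: the limit of > 10000 nM in this assay, at which 1 of the 3 values shown sits.

The compounds shown leave open whether another small group at the carbon ortho to an amino group, such as fluoro, methyl or methoxy, would give a lower or a higher number than compound 3 does at 250 nM. They also leave open how the core behaves with neither chloro group, and whether the contrast between the two carbons holds when the chloro group that remains in compound 3 is replaced by bromo or by a nitrile.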